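Furan-3-yl in place of thiophen-3-yl on compound 1

A few compounds are considered here, and "the series" means these few. Any claim that something is new, unique, unknown or untested is made for them only; others in the source may bear on it.

The study measured three compounds in a functional assay on HCT-116 cells (Homo sapiens), read by MTT assay, with a stated time of 72 h (a higher number here means a weaker inhibitor, a lower number a stronger inhibitor), and leaves a fourth to be estimated. Compound 1 `O=c1[nH]cnc2c1c(-c1ccsc1)cn2[C@@H]1O[C@H](CO)[C@@H](O)[C@H]1O` carries a thiophen-3-yl group on its core. In this assay compound 1 gives > 20000 nM, which is a limit of the assay and not a number. Compound 3 `Nc1nc(N)c2c(-c3ccccc3)cn([C@@H]3O[C@H](CO)[C@@H](O)[C@H]3O)c2n1` also reaches only a limit in this assay, at > 20000 nM. Within the data shown here, compound 2 `C#Cc1cn([C@@H]2O[C@H](CO)[C@@H](O)[C@H]2O)c2ncnc(N(C)C)c12` is the one compound with a measured number, giving 180 nM in this assay. Compound 1 therefore stands at the weak end of what is shown, with the limit of > 20000 nM in this assay, at which 2 of the 3 values shown sit.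

Compound 4 `O=c1[nH]cnc2c1c(-c1ccoc1)cn2[C@@H]1O[C@H](CO)[C@@H](O)[C@H]1O` differs from compound 1 in one place: furan-3-yl in place of thiophen-3-yl on an aromatic carbon. Among the measured compounds shown here, no measured pair in the set shows a step of this kind, so its size is not known from the data. The change is small in count, and the expectation is that the step from compound 1 to compound 4 in this assay stays within the scatter, that is a step that the limit leaves unreadable from compound 1 to compound 4. Compound 4 is accordingly expected to give about 30000 nM in this assay, most likely again only a limit, within a range from 6000 nM to 150000 nM.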

Compound 4, half-maximal inhibitory concentration: 10300 nM
Compound 4: middle estimate off by 2.9-fold (0.46 log units), on the high side, and the stated range covers the measured number.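

In this assay, the change from thiophen-3-yl to furan-3-yl on this aromatic carbon turns a limit into a measured number, which gives this position its first readable value on the core of compound 1. The two groups match in heavy-atom count, hydrogen-bond donors and hydrogen-bond acceptors, and the exchange of sulfur for oxygen in the ring comes to an at least 1.9-fold lower number from compound 1 to compound 4 (0.28 log units; that floor lies within the scatter). That step is only a floor and its true size cannot be read, because compound 1 stands at a limit of the assay: the limit of > 20000 nM in this assay, at which 2 of the 4 values shown sit.

The compounds shown leave open how this position responds to anything other than these two rings on the core of compound 1, such as a pyridine ring, an amine or a longer alkyl chain in place of furan-3-yl. As far as these compounds go, whether the same exchange of thiophen-3-yl for furan-3-yl would move the number on a core like that of compound 2, which reads well clear of the limit, also stays open.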